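The source may report more compounds than this note shows. Statements on the series, on what has been measured and on what is new or still open speak of the compounds shown alone.

Measured in a functional assay on NCI-H460 cells (Homo sapiens) for inhibition, read by MTT assay, with a stated time of 24 h, tested at 100 ug/mL; on this read-out lower numbers stand for less inhibition of growth and higher numbers for more inhibition of growth at the one concentration tested:
- compound 1 `O=C(CCCCC1CCSS1)NO`: "not active" (no number reported)
- compound 2 `O=C(CCCCC1CCSS1)Nc1ccc([N+](=O)[O-])c(C(F)(F)F)c1`: 51.7%
- compound 3 `O=C(CCCCC1CCSS1)Nc1ccccn1`: 39.3%

Of the two numeric results, the lower belongs to compound 3 at 39.3%. Compound 2 gives 51.7%, and the gap between the two lies beyond the usual scatter. Compound 1 has no number to compare.

Compound 4 `O=C(CCCCC1CCSS1)Nc1ccc(Cl)cn1` departs from compound 3 at a single place: chloro in place of hydrogen on an aromatic carbon. This is chloro in place of hydrogen on an aromatic carbon. Among the compounds with values here, the series offers no measured single-place step, so nothing here shows directly what this change does in this assay. Within the data shown here, the only guide is the numeric range, with compound 2 at 51.7% as its upper mark, and compound 2 differs from compound 3 in more than one place. A small upward move is expected, possibly none beyond the scatter. The expected change is a number 5.7 percentage points higher from compound 3 to compound 4 (within the scatter). For compound 4 the estimated value is 45%, with an expected range of 30% to 60%.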

Compound 4, percent growth inhibition at one concentration: 58.6%
Compound 4: the middle estimate sits 13.6 percentage points below what was measured; the range from low to high includes it.
By their numbers in this assay, from the lowest: compound 3; then compounds 2 and 4 (each within the scatter of the next).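

In this assay, within the data shown here, replacing hydrogen with chloro on the aromatic carbon two atoms from the ring nitrogen, para to a large group, gives the first single-place step: a number 19.3 percentage points higher from compound 3 to compound 4 (beyond the scatter). This shows that the position is not silent in this assay, since a change of 1 heavy atom is enough to move growth inhibition past the usual scatter. No measured information bears on why the chloro has this effect.

From the compounds shown here alone, it remains open whether the gain is specific to chloro or would also appear with a fluoro, a bromo, a methyl or an amine at the same carbon. The compounds shown also leave open whether chloro on another carbon of the ring would give a similar step.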